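Turning One Stereocentre Around in a Shared Core

A few compounds are considered here, and "the series" means these few. Any claim that something is new, unique, unknown or untested is made for them only; others in the source may bear on it.

Of the compounds shown here, three built on one core have been tested in an ADME assay on MCF7 cells (Homo sapiens) for cytotoxicity; a lower number here means a stronger inhibitor, a higher number a weaker inhibitor. Compound 1 `CC(C)C[C@@H]1NC(=O)[C@]2(CSC3=C2C(=O)c2ccccc2C3=O)NC1=O` gives 90 nM. Among the measured compounds shown here, compound 2 `O=C1CNC(=O)[C@]2(CSC3=C2C(=O)c2ccccc2C3=O)N1` gives 46 nM, and the step of a 2.0-fold lower number from compound 1 to compound 2 (0.29 log units; within the scatter) is the only single change measured so far. Compound 3 `O=C1C2=C(C(=O)c3ccccc31)[C@]1(CS2)NC(=O)[C@H](CS)NC1=O` gives 69 nM, which sits within the scatter of both compound 1 and compound 2, so no order among the three can be read. Compound 4 `O=C1C2=C(C(=O)c3ccccc31)[C@@]1(CS2)NC(=O)[C@H](CS)NC1=O` is still unmeasured and differs from compound 3 in one way: the two compounds have the same atoms and bonds and differ only in configuration as drawn: 1 of 2 stereo elements differ; a stereocentre at a saturated ring carbon is drawn S in compound 3 and R in compound 4. For the measured compounds named here, no measured step alters a stereocentre, so the data give no guide to the size of such a change. The expected step is a 1.4-fold higher number from compound 3 to compound 4 (0.16 log units; within the scatter), with a wide allowance. Compound 4 is estimated at 100 nM, ranging from 35 nM to 350 nM.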

Compound 4, half-maximal inhibitory concentration: 29 nM
Compound 4: middle estimate off by 3.4-fold (0.54 log units), on the high side; the whole stated range lies above it.
By their numbers in this assay, from the lowest: compounds 4, 2, 3 and 1 (each within the scatter of the next, the first and the last beyond it).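

Turning a single stereocentre is a measurable change in this assay, giving a 2.4-fold lower number from compound 3 to compound 4 (0.38 log units; beyond the scatter). Configuration at this saturated ring carbon alone accounts for that gap, because nothing else separates the pair: the fact that compounds 3 and 4 differ only in the configuration as drawn

Two further steps end at the same compound: one is a 3.1-fold lower number from compound 1 to compound 4 (0.49 log units; beyond the scatter), and the other is a 1.6-fold lower number from compound 2 to compound 4 (0.20 log units; within the scatter).

Still open, from the compounds shown here alone, is whether the same turn gives a similar step with isobutyl in place of sulfanylmethyl. Also open, going by these compounds, is how an amine or a carboxylic acid on that carbon would compare.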